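The source may hold more compounds than are shown below. What is called first, only, known or untested is meant among the compounds shown, and "the series" means these compounds.

In a functional assay on the whole organism (strain CF-1 albino) with Mus musculus as the target, with a stated time of 4 h (on this read-out lower numbers stand for an effect already at smaller amounts and higher numbers for an effect only at larger amounts of compound), compound 3, with the structure `O=C1CC(c2ccccc2F)C(=O)N1CN1CCN(c2ncccn2)CC1`, gives 100 mg/kg. Compound 1, `O=C1CC(c2ccccc2Br)C(=O)N1CN1CCN(c2ccc(F)cc2)CC1`, gives 100 mg/kg in this assay, the same number as compound 3 at the digits shown, so the two stand together at the lowest point of the three; compound 2, `O=C1CC(c2ccccc2Br)C(=O)N1CN1CCN(c2ccccc2Cl)CC1`, gives 300 mg/kg, and the step of a 3.0-fold higher number from compound 1 to compound 2 (0.48 log units; beyond the scatter) lies beyond the scatter. Compound 4, `O=C1CC(c2ccccc2Br)C(=O)N1CN1CCN(c2ncccn2)CC1`, has not yet been measured in this assay. It differs from compound 3 by bromo in place of fluoro on an aromatic carbon. Within the data shown here, no measured step changes this position: the one step recorded, from compound 1 to compound 2, alters the group on the amine nitrogen in a ring instead. Compound 1 and compound 2 both carry bromo at the place where compound 3 carries fluoro, and compound 1 gives the same number as compound 3. The expected step of no change at the digits printed from compound 3 to compound 4 (within the scatter) is therefore no change beyond the scatter. Compound 4 is estimated at 100 mg/kg, within 50 mg/kg to 300 mg/kg.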

Compound 4, minimum effective dose: 100 mg/kg
Estimate against measurement, compound 4: no gap at the digits printed; the range from low to high includes it.
By their numbers in this assay, from the lowest: compounds 1, 3 and 4 (each within the scatter of the next); then compound 2.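

In this assay, among these compounds, bromo in place of fluoro on the aromatic carbon, with pyrimidin-2-yl held on the amine nitrogen, gives no change at the digits printed from compound 3 to compound 4 (within the scatter), the first direct reading of this change at this position. With bromo held, pyrimidin-2-yl in place of 2-chlorophenyl gives a 3.0-fold lower number from compound 2 to compound 4 (0.48 log units; beyond the scatter), while pyrimidin-2-yl in place of 4-fluorophenyl gives no change at the digits printed from compound 1 to compound 4 (within the scatter), so among these compounds the only steps beyond the scatter involve the 2-chlorophenyl group, not the change of halogen. No measurement is available to explain these numbers.

On these data alone, the halogen change has been read only with pyrimidin-2-yl on the amine nitrogen, so its outcome with 2-chlorophenyl or 4-fluorophenyl there remains open. Also open, as far as these compounds go, is how a methoxy group or an amine would fare on the aromatic carbon in place of the halogen.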